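A few compounds are considered here, and "the series" means these few. Any claim that something is new, unique, unknown or untested is made for them only; others in the source may bear on it.

Measured compounds: compound 1 `O=C(COc1ccc2c(=O)ccoc2c1)Nc1cccc(NC(=O)c2ccc([N+](=O)[O-])cc2)c1` and compound 2 `Cc1nc(C(=O)Nc2cccc(NC(=O)COc3ccc4c(=O)ccoc4c3)c2)cs1`.

In an assay on isolated protein for inhibition of Rho-associated protein kinase 2 (Homo sapiens), read by scintillation counting, radiometric assay and 33P incorporation, with a stated time of 40 min, in the presence of a further agent that is not named here (on this read-out lower numbers stand for stronger inhibition and higher numbers for weaker inhibition), compound 1 gives 15 nM. In this assay, going by the values given here, compound 2 gives 33 nM, the higher of the two numbers, with the only measured step being a 2.2-fold higher number from compound 1 to compound 2 (0.34 log units; beyond the scatter).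

Compound 3 `Cc1cc(C(=O)Nc2cccc(NC(=O)COc3ccc4c(=O)ccoc4c3)c2)no1` differs from compound 2 in one place: 5-methyl-1,2-oxazol-3-yl in place of 2-methyl-1,3-thiazol-4-yl on a carbonyl carbon. Among the compounds with values here, the one measured step that bears on this change, a 2.2-fold higher number from compound 1 to compound 2 (0.34 log units; beyond the scatter), exchanges one carbonyl-bound group for another and shifts the number only modestly. The present change swaps one five-membered aromatic ring with two hetero atoms for another of the same size and count, a smaller change than that earlier one. Compound 3 is therefore expected to show no step beyond the scatter, with the estimated step of a 1.2-fold higher number from compound 2 to compound 3 (0.08 log units; within the scatter). The expected value for compound 3 in this assay is 40 nM, within a range from 14 nM to 115 nM.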

Compound 3, half-maximal inhibitory concentration: 5 nM
For compound 3 the middle estimate is 8.0-fold (0.90 log units) above the measured one; measured number outside the range, below it.
By their numbers in this assay, from the lowest: compound 3; then compound 1; then compound 2.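

At this place, on a carbonyl carbon bound to an amide-type nitrogen, the two five-membered aromatic rings are not interchangeable in this assay: 5-methyl-1,2-oxazol-3-yl in place of 2-methyl-1,3-thiazol-4-yl gives a 6.6-fold lower number from compound 2 to compound 3 (0.82 log units; beyond the scatter), although the two groups match in heavy atoms, hydrogen-bond donors and acceptors. Set against 4-nitrophenyl, the same group gives a 3.0-fold lower number from compound 1 to compound 3 (0.48 log units; beyond the scatter), so a five-membered ring here can end on either side of 4-nitrophenyl, and compound 3 is the strongest of the three. Nothing available explains this difference.

On these data alone, what a 2-methyl-1,3-oxazol-4-yl or an unsubstituted 1,2-oxazol-3-yl group would give on this carbonyl carbon stays open. So does the question of whether the ring oxygen, the order of the ring atoms or the methyl carries the step.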